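The source may hold more compounds than are shown below. What is called first, only, known or untested is meant among the compounds shown, and "the series" means these compounds.

Measured so far in an ADME assay on Huh-7 cells (Homo sapiens) for cytotoxicity, with a stated time of 72 h (a higher number here means that more compound is tolerated, a lower number that less compound is tolerated), each entry a limit:
- compound 1 `CCC(C)CCn1nc(-c2cccs2)c(O)c(C2=NS(=O)(=O)c3cc(NS(C)(=O)=O)ccc3N2)c1=O`: > 1000 nM
- compound 2 `CS(=O)(=O)Nc1ccc2c(c1)S(=O)(=O)N=C(c1c(O)c(-c3cccs3)nn(CCC3CC3)c1=O)N2`: > 33000 nM
- compound 3 `CS(=O)(=O)Nc1ccc2c(c1)S(=O)(=O)N=C(c1c(O)c(-c3cccs3)nn(CC3(C(F)(F)F)CC3)c1=O)N2`: > 1000 nM

Compound 3 gives > 1000 nM, which is a limit and not a number. For the measured compounds named here, the series so far sits at two limits: the limit of > 1000 nM in this assay, at which 2 of the 3 values shown sit, and (the limit of > 33000 nM in this assay, at which 1 of the 3 values shown sits).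

Compound 4 `CS(=O)(=O)Nc1ccc2c(c1)S(=O)(=O)N=C(c1c(O)c(-c3cccs3)nn(Cc3ccc(F)cc3)c1=O)N2` carries 4-fluorophenyl in place of 1-(trifluoromethyl)cyclopropyl on a saturated chain carbon bound to an aromatic nitrogen. Cut one bond further out, the same change reads (1-(trifluoromethyl)cyclopropyl)methyl to 4-fluorobenzyl.

Going by the values given here, three measured steps bear on it, all changes at this same chain: a step that the two limits leave unreadable from compound 1 to compound 3, a step that the two limits leave unreadable from compound 2 to compound 3 and a step that the two limits leave unreadable from compound 1 to compound 2. Among the compounds with values here, none of them has a readable size, and no measured compound carries 4-fluorophenyl, so no size or direction can be carried over to this assay. Within the data shown here, compound 2 is the only guide to how high the range may reach, with > 33000 nM, which is a limit. The expected step is a step that the limit leaves unreadable from compound 3 to compound 4, estimated with no measurable loss of tolerance. Compound 4 is estimated at 20000 nM, with an expected range of 3000 nM to 50000 nM, and a limit is the likely report.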

Compound 4, half-maximal cytotoxic concentration: > 1000 nM
Compound 4 ended at the assay's limit (the forecaster's own chance of this, stated with the estimate: 85%); the middle value lies beyond the limit too.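

In this assay compound 4 gives > 1000 nM, which is a limit. Its steps from compound 1, compound 2 and compound 3 therefore cannot be read, and no new comparison arises. The compounds shown leave open whether any of these chains, 4-fluorobenzyl included, changes tolerance at all, as none has a value that is not a limit.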